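Capping the Phenol: From Compound 1 to Compound 3

A few compounds are considered here, and "the series" means these few. Any claim that something is new, unique, unknown or untested is made for them only; others in the source may bear on it.

Compound 1 `COc1cc2c(/C=C3/C(=O)Nc4ccc(O)cc43)c(Cl)n(Cc3cc(OC)c(OC)c(OC)c3)c2cc1C` gives 2290 nM in a functional assay on cells (Cancer cell lines, Homo sapiens) for cytotoxicity, with a stated time of 48 h; a higher number here means a weaker inhibitor of growth, a lower number a stronger inhibitor of growth. Compound 2 `O=C1/C(=C/c2c(Cl)[nH]c3ccccc23)c2ccccc2N1Cc1ccccc1` gives 4170 nM in this assay.

Compound 1 has the lower of the two numbers, but compound 2 lies within the scatter of it, so no order between them is established. Compound 3 `COc1ccc2c(c1)/C(=C\c1c(Cl)n(Cc3cc(OC)c(OC)c(OC)c3)c3cc(C)c(OC)cc13)C(=O)N2` differs from compound 1 by methyl in place of hydrogen on an oxygen on an aromatic ring. Among the measured compounds shown here, no measured pair shows this change, so the expected step of a 1.3-fold higher number from compound 1 to compound 3 (0.12 log units; within the scatter) is a small one, in no direction beyond the scatter. Compound 3 is therefore estimated at 3000 nM, within a range from 1200 nM to 8000 nM.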

Compound 3, concentration for 50% growth inhibition: 11000 nM
For compound 3 the middle estimate is 3.7-fold (0.56 log units) below the measured one; the measured number lies above the stated range.
By their numbers in this assay, from the lowest: compounds 1 and 2 (each within the scatter of the next); then compound 3.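

Replacing hydroxy with methoxy on the aromatic ring gives, in this assay, a 4.8-fold higher number from compound 1 to compound 3 (0.68 log units; beyond the scatter) as the only readable step among the compounds shown. At this position, the free hydroxy therefore goes with the lower number, and capping its oxygen with a single methyl is enough to move the value beyond the scatter. No measurement shown here accounts for this step.

The compounds shown leave open whether ethoxy on the same oxygen would read like methoxy, and where an amine in place of the hydroxy would fall. A single pair also cannot show whether the step would recur on another core.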